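Benzylsulfanyl variation on the aryl sulfonyl guanidine series

This account rests on a few compounds, and the source may have more. Where it says the series, first, only, none or still open, it means among the compounds named here.

Measured compounds:
- compound 1 `Cc1cc(S(=O)(=O)/N=C(\N)n2nccc2-c2ccccc2)c(SCc2ccccc2Cl)cc1Cl`: 18000 nM
- compound 2 `Cc1cc(-c2ccccc2)n(/C(N)=N/S(=O)(=O)c2cc(C)c(Cl)cc2SCc2ccccc2C(F)(F)F)n1`: 25000 nM
- compound 3 `Cc1ccc(CSc2cc(Cl)c(C)cc2S(=O)(=O)/N=C(\N)n2nccc2-c2ccccc2)cc1`: 14000 nM

All three numbers come from a functional assay on HCT-116 cells (Homo sapiens) for cytotoxicity, read by MTT assay, with a stated time of 72 h; a lower number here means a stronger inhibitor, a higher number a weaker inhibitor. Compound 2 has the highest of the three numbers, but its gaps to compound 1 and to compound 3 both lie within the scatter, so no order among the three can be read from these values.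

The unmeasured compound 4 `Cc1cccc(CSc2cc(Cl)c(C)cc2S(=O)(=O)/N=C(\N)n2nc(C)cc2-c2ccccc2)c1` is reached from compound 2 by a single change at the benzyl group: 3-methylphenyl in place of 2-(trifluoromethyl)phenyl on a saturated chain carbon bound to a sulfur.

Among the compounds with values here, the one measured step at the same place, a 1.3-fold lower number from compound 1 to compound 3 (0.11 log units; within the scatter), is within the scatter. That step swaps one substituted phenyl on the saturated chain carbon bound to a sulfur for another, as does the change from compound 2 to compound 4; it gives no sign that this position moves the number in this assay beyond the usual variation. Within the data shown here, with only one such step available, the expectation is weak, and no step beyond the scatter is expected.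

Compound 4 is therefore expected to sit close to compound 2, with the estimated step of a 1.4-fold lower number from compound 2 to compound 4 (0.14 log units; within the scatter), and an estimated value of 18000 nM, in a range from 8000 nM to 40000 nM.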

Compound 4, half-maximal inhibitory concentration: 34000 nM
Beside the measured number, compound 4's estimate is 1.9-fold (0.28 log units) below it; the range from low to high includes it.
By their numbers in this assay, from the lowest: compounds 3, 1, 2 and 4 (each within the scatter of the next, the first and the last beyond it).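

In this assay, the swap at the saturated chain carbon bound to a sulfur gives a 1.4-fold higher number from compound 2 to compound 4 (0.13 log units; within the scatter), so a second step at this place stays within the scatter, this time with 2-(trifluoromethyl)phenyl, 10 heavy atoms, giving way to 3-methylphenyl, 7 heavy atoms. Taken with a 1.3-fold lower number from compound 1 to compound 3 (0.11 log units; within the scatter), that makes two swaps of one substituted phenyl for another at this place, neither of which separates its pair, so no trend can be read from them. Nothing measured here accounts for the size of either step.

The compounds shown leave open whether an amine or a carboxylic acid on this phenyl, or a longer chain in place of the benzyl group, would give a step beyond the scatter. Within the data shown here, every group at this place so far is a phenyl carrying a chlorine, a methyl or a trifluoromethyl.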